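From isopropyl to dichloro on the benzyl arm

The compounds below may be only part of what the source reports. "The series", "measured", "known", "first", "only" and "open" are said of these compounds alone.

Measured in a functional assay on HEK293 cells for agonist activity at G-protein coupled receptor 39 (Homo sapiens), read by scintillation proximity assay and inositol phosphate accumulation, with a stated time of 75 min; on this read-out lower numbers stand for an effect already at smaller amounts and higher numbers for an effect only at larger amounts of compound:
Compound 1 `Cc1nn(-c2ncnc3nc[nH]c23)c2c1C(c1ccc(OC(C)C)cc1)CC(=O)N2` gives 2700 nM
Compound 2 `Cc1nn(-c2ncnc3nc[nH]c23)c2c1C(OCc1ccc(C(C)C)cc1)CC(=O)N2` gives 1690 nM

Compound 2 holds the lower of the two numbers, and compound 1 sits so close to it that the gap lies within the scatter; the two cannot be told apart. Compound 3 `Cc1nn(-c2ncnc3nc[nH]c23)c2c1C(OCc1ccc(Cl)cc1Cl)CC(=O)N2` differs from compound 2 by 2,4-dichlorophenyl in place of 4-isopropylphenyl on a saturated chain carbon bound to an oxygen on a saturated carbon. Within the data shown here, no measured pair shows such a change, so its size is unknown; in this assay a step of no more than the scatter is expected, in no firm direction. Compound 3 is therefore estimated at 1500 nM, between 500 nM and 5000 nM, meaning an expected step of a 1.1-fold lower number from compound 2 to compound 3 (0.05 log units; within the scatter).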

Compound 3, half-maximal effective concentration: 243 nM
The estimate for compound 3 lay 6.2-fold (0.79 log units) above the measured number; the whole stated range lies above it.
By their numbers in this assay, from the lowest: compound 3; then compounds 2 and 1 (each within the scatter of the next).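

This position responds to what the benzyl arm carries: 2,4-dichlorophenyl in place of 4-isopropylphenyl gives a 7.0-fold lower number from compound 2 to compound 3 (0.84 log units; beyond the scatter) in this assay, a separation that compounds 1 and 2 never showed. Against the 4-isopropoxyphenyl arm, (2,4-dichlorobenzyl)oxy gives an 11-fold lower number from compound 1 to compound 3 (1.05 log units; beyond the scatter). Nothing measured here accounts for this gain.

Among these compounds, whether both chlorines are needed remains open, since only the pair appears here. So does whether a methoxy group or a carboxylic acid on that ring would keep the lower number.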